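The source may hold more compounds than are shown below. What is called first, only, known or untested is meant among the compounds shown, and "the series" means these compounds.

The series rests on the core of compound 1 `Cc1ccc(S(=O)(=O)N2CC=C(Cl)CC2)cc1`. In a functional assay on SW1573 cells (Homo sapiens) for antiproliferative activity, read by sulforhodamine B assay, with a stated time of 48 h (on this read-out higher numbers stand for weaker inhibition of growth and lower numbers for stronger inhibition of growth), compound 1 gives > 100000 nM, which is a limit of the assay rather than a number. Compound 2 `Cc1ccc(S(=O)(=O)N2CC=C(Br)CC2)cc1` carries bromo in place of chloro on a double-bonded ring carbon. In this assay compound 2 gives > 100000 nM, again a limit of the assay and not a number. The step that the two limits leave unreadable from compound 1 to compound 2 cannot be read because both values sit at the limit of > 100000 nM in this assay, at which 2 of the 2 values shown sit. Compound 2 therefore stands only at that limit, with no number shown for it. Compound 3 `Cc1ccc(S(=O)(=O)N2CCC(Br)=CC2C2CCCCC2)cc1` differs from compound 2 by cyclohexyl in place of hydrogen on a saturated ring carbon. No measured step speaks to this change, as the only step shown is unreadable. In this assay the step expected is an at least 2.0-fold lower number from compound 2 to compound 3 (0.30 log units; that floor lies within the scatter), not anchored by any measurement. Compound 3 is estimated at 50000 nM, with a range from 10000 nM to 200000 nM.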

Compound 3, concentration for 50% growth inhibition: 65000 nM
Estimate against measurement, compound 3: 1.3-fold (0.11 log units) below; the measured number falls inside the stated range.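

Going by these compounds alone, with cyclohexyl on a saturated ring carbon, next to the ring nitrogen, compound 3 gives the first number of the series in this assay, and the change reads as an at least 1.5-fold lower number from compound 2 to compound 3 (0.18 log units; that floor lies within the scatter) at this position. Within the data shown here, this makes it the first change that can be read at all, though only as a floor that does not clearly separate the two compounds. On these data alone, the true size of the step stays open because compound 2 carries a limit and no number: the limit of > 100000 nM in this assay, at which 2 of the 3 values shown sit.

The compounds shown leave open whether a smaller group such as methyl, an aromatic group such as phenyl, or an amine at this same place would give a number, and how large it would be. They also leave open whether chloro in place of bromo still makes no readable difference once cyclohexyl is present.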